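The source may hold more compounds than are shown below. What is called first, only, known or untested is meant among the compounds shown, and "the series" means these compounds.

Compound 2 (`CCCCc1ccc(C(=O)/C=C/C(=O)O)cc1`) gives 6740 nM in a functional assay on LS174T cells (Homo sapiens) for inhibition, read by MTT assay, with a stated time of 72 h; a lower number here means a stronger inhibitor, a higher number a weaker inhibitor. Compound 3 (`CCc1ccc(C(C)C)cc1C(=O)/C=C/C(=O)O`) gives 5940 nM, a value within the usual scatter of compound 2. Compound 1 (`CCc1ccc(C(=O)/C=C/C(=O)O)cc1`) gives 21000 nM, a clearly higher number than either, so it is the weakest inhibitor of the three.

The next compound, compound 4 (`O=C(O)/C=C/C(=O)c1ccc(F)cc1`), has not yet been measured. It differs from compound 2 as follows: fluoro in place of butyl on an aromatic carbon.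

Among the compounds with values here, no measured compound carries fluoro, so no step speaks to that group directly. The nearest guide is a 3.1-fold lower number from compound 1 to compound 2 (0.49 log units; beyond the scatter), the change from ethyl to butyl at the same place, which is modest but beyond the scatter. Read in reverse, that single step suggests that a smaller group at this place gives a higher number in this assay. Within the data shown here, compound 3 differs from compound 2 in more than one place, so it offers no clean step here.

A move towards weaker inhibition, of about the same modest size, therefore seems likely. The expected change is a 3.0-fold higher number from compound 2 to compound 4 (0.47 log units; beyond the scatter). For compound 4 the estimated value is 20000 nM, with an expected range from 8000 nM to 50000 nM.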

Compound 4, half-maximal inhibitory concentration: 33800 nM
Compound 4: middle estimate off by 1.7-fold (0.23 log units), on the low side, within the range that was stated.
By their numbers in this assay, from the lowest: compounds 3 and 2 (each within the scatter of the next); then compounds 1 and 4 (each within the scatter of the next).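

Taking butyl out for fluoro at this aromatic carbon in this assay gives a 5.0-fold higher number from compound 2 to compound 4 (0.70 log units; beyond the scatter), so the advantage of butyl seen in the earlier ethyl-to-butyl step also holds against a group of a different kind. Fluoro in place of ethyl gives a 1.6-fold higher number from compound 1 to compound 4 (0.21 log units; within the scatter), which lies within the scatter, so this assay does not separate these two groups even though one is a single fluorine atom and the other a carbon chain. Among compounds 1, 2 and 4, which differ only at this place, butyl alone stands apart, and nothing available explains why.

A longer chain such as hexyl could show whether the number keeps falling as the chain grows or levels off after butyl, and a branched group such as tert-butyl could show whether the shape of the chain matters as well as its length. As far as these compounds go, with only ethyl, butyl and fluoro at this place, the effect of very different groups, such as an amine or a methoxy group, also remains open.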